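A few compounds are considered here, and "the series" means these few. Any claim that something is new, unique, unknown or untested is made for them only; others in the source may bear on it.

Measured compounds:
compound 1, `O=C(Nc1cccc(-n2cc(-c3ccncc3)c(-c3ccc(Cl)c(O)c3)n2)c1)Nc1cccc(C(F)(F)F)c1`, 1440 nM
compound 2, `COc1cc(-c2nn(-c3cccc(NC(=O)Nc4ccc(Cl)c(Cl)c4)c3)cc2-c2ccncc2)ccc1Cl`, 890 nM

In a functional assay on K562 cells (Homo sapiens) for inhibition, read by sulforhodamine B assay, with a stated time of 48 h (a lower number here means a stronger inhibitor of growth, a higher number a weaker inhibitor of growth), compound 2 gives 890 nM, and compound 1 gives 1440 nM; the two numbers lie within the scatter of each other, so neither is set apart from the other. Compound 3, `O=C(Nc1cccc(-n2cc(-c3ccncc3)c(-c3ccc(Cl)c(O)c3)n2)c1)Nc1ccc(Cl)c(Cl)c1`, is not yet measured. It differs from compound 2 by hydrogen in place of methyl on an oxygen on an aromatic ring. For the measured compounds named here, no measured pair shows this change alone. Compound 1 already carries the hydroxy group in a different setting, and its value lies close to that of compound 2. The step of a 1.1-fold higher number from compound 2 to compound 3 (0.05 log units; within the scatter) is expected to stay within the scatter. Compound 3 is estimated at 1000 nM, between 400 nM and 2500 nM.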

Compound 3, concentration for 50% growth inhibition: 1410 nM
Beside the measured number, compound 3's estimate is 1.4-fold (0.15 log units) below it; the range from low to high includes it.
By their numbers in this assay, from the lowest: compounds 2, 3 and 1 (each within the scatter of the next).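

In this assay, 4-chloro-3-hydroxyphenyl in place of 4-chloro-3-methoxyphenyl, now seen alone, gives a 1.6-fold higher number from compound 2 to compound 3 (0.20 log units; within the scatter), so this change at this oxygen on an aromatic ring shifts the number by no more than the scatter. Compound 3 also isolates a second change, 3,4-dichlorophenyl in place of 3-(trifluoromethyl)phenyl on an amide-type nitrogen, which gives a 1.0-fold lower number from compound 1 to compound 3 (0.01 log units; within the scatter). Nothing offered here accounts for either result. The compounds shown leave open whether an ethoxy group or a longer chain on that oxygen, or an amine in place of the hydroxy group, would move the number beyond the scatter.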